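Removing a Bromo Group in Two Related Series

A few compounds are considered here, and "the series" means these few. Any claim that something is new, unique, unknown or untested is made for them only; others in the source may bear on it.

Compound 1, `O=C1C(=O)N(CN2CCN(c3ccnc4cc(Cl)ccc34)CC2)c2cccc(Br)c21`: 15100 nM in a functional assay on MCF7 cells (Homo sapiens) for cytotoxicity, read by sulforhodamine B assay, with a stated time of 48 h; on this read-out lower numbers stand for stronger inhibition of growth and higher numbers for weaker inhibition of growth
Compound 2, `O=C1C(=O)N(CN2CCN(c3ccnc4cc(Cl)ccc34)CC2)c2ccccc21`: 48300 nM
Compound 3, `NC(=S)N/N=C1/C(=O)N(CN2CCN(c3ccnc4cc(Cl)ccc34)CC2)c2cc(Br)ccc21`: 11400 nM

Compound 1 and compound 2 differ by hydrogen in place of bromo on an aromatic carbon and the measured step is a 3.2-fold higher number from compound 1 to compound 2 (0.50 log units; beyond the scatter). Compound 3 carries a different core from compound 1; the difference between the two cores is not broken down here. Compound 4, `NC(=S)N/N=C1/C(=O)N(CN2CCN(c3ccnc4cc(Cl)ccc34)CC2)c2ccccc21`, is not yet measured and differs from compound 3 by hydrogen in place of bromo on an aromatic carbon. The surroundings are not identical: in compound 1 the bromo sits ortho to a fused ring and meta to a fused ring, in compound 3 meta to a fused ring and para to a fused ring, so this is the same kind of change rather than the same change. In this assay the step is expected to be a 2.6-fold higher number from compound 3 to compound 4 (0.42 log units; beyond the scatter), similar in direction and size, because the earlier step was a 3.2-fold higher number from compound 1 to compound 2 (0.50 log units; beyond the scatter). Compound 4 is therefore estimated at 30000 nM, probably between 12000 nM and 80000 nM.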

Compound 4, concentration for 50% growth inhibition: 23000 nM
Compound 4: the middle estimate sits 1.3-fold (0.12 log units) above what was measured; the measured number falls inside the stated range.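

In this assay, putting hydrogen in place of bromo gives a 2.0-fold higher number from compound 3 to compound 4 (0.30 log units; within the scatter). The two steps agree as closely as such measurements can show, so the change appears to carry from one core to the other: the same change on two cores in this assay, a 3.2-fold higher number (0.50 log units; beyond the scatter) from compound 1 to compound 2 and a 2.0-fold higher number (0.30 log units; within the scatter) from compound 3 to compound 4, 1.6-fold (0.20 log units) apart, within the scatter of two such steps. This does not establish a real loss of growth inhibition on the core of compound 3, as its step alone lies within the scatter, and two pairs with the bromo in different surroundings make no general rule.

From the compounds shown here alone, it remains open whether a chloro, methyl or methoxy group in place of bromo would behave similarly on these cores. An amine or a carboxylic acid at the same positions is also untested among the compounds shown.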